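Reversing the amide on the aryl ring of compound 3

The source may report more compounds than this note shows. Statements on the series, on what has been measured and on what is new or still open speak of the compounds shown alone.

Measured so far in an ADME assay on microsomes from liver (Homo sapiens) for metabolic stability, read by LC-MS, using NADPH; a higher number here means that the compound lasts longer, a lower number that the compound disappears faster:
compound 1 `O=C(O)c1cccc(-c2csc(Nc3ccccc3F)n2)c1`: 1.61 h
compound 2 `Fc1ccccc1Nc1nc(-c2ccccc2)cs1`: 0.36 h
compound 3 `CNC(=O)c1cccc(-c2cnc(Nc3ccc(F)cc3)o2)c1`: 0.423 h

Compound 3 stands second highest of these three numbers in this assay; its value and that of compound 2 lie within the scatter of each other, while compound 1 sits beyond the scatter above it. Compound 4 `CC(=O)Nc1cccc(-c2cnc(Nc3ccc(F)cc3)o2)c1` differs from compound 3 by acetamido in place of methylcarbamoyl on an aromatic carbon. Among the measured compounds shown here, the only measured step, a 4.5-fold lower number from compound 1 to compound 2 (0.65 log units; beyond the scatter), concerns a different change on a different core and therefore says little about this swap; no measured pair bears on it directly. A step of no more than the scatter is expected, so a 1.1-fold higher number from compound 3 to compound 4 (0.03 log units; within the scatter) is the estimated change. Compound 4 is thus expected to give about 0.45 h, within the range 0.18 h to 1.1 h.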

Compound 4, half-life: 1.91 h
Compound 4: the middle estimate sits 4.2-fold (0.63 log units) below what was measured; the whole stated range lies below it.
By their numbers in this assay, from the lowest: compounds 2 and 3 (each within the scatter of the next); then compounds 1 and 4 (each within the scatter of the next).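

Reversing the amide on the aromatic carbon gives a 4.5-fold higher number from compound 3 to compound 4 (0.65 log units; beyond the scatter) in this assay, so this position is sensitive to how the same atoms are joined and not only to which atoms are there. The earlier step concerned hydrogen in place of carboxy on a different core, whereas here the heavy atoms, donors and acceptors counted for the two groups match. Nothing available accounts for the step. Going by these compounds, whether an amine, a carboxylic acid or a longer chain at this place would keep the number of compound 4 remains open. So does whether the same reversal would act alike on the core of compound 1.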